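Hydroxy in place of fluoro: notes toward compound 4

The compounds below may be only part of what the source reports. "The series", "measured", "known", "first", "only" and "open" are said of these compounds alone.

Measured so far in a functional assay on P388 cells (Mus musculus) for antiproliferative activity, with a stated time of 72 h; a lower number here means that less compound is needed, a higher number that more compound is needed for the effect:
Compound 1, `Cc1cn([C@@H]2O[C@H](CO)[C@@H](CN)[C@@H]2O)c(=O)[nH]c1=O`: > 100 uM, a limit.
Compound 2, `Cc1cn([C@H]2C[C@H](CO)[C@@H](CO)O2)c(=O)[nH]c1=O`: 5 uM.
Compound 3, `Cc1cn([C@@H]2O[C@H](CO)[C@@H](CF)[C@@H]2O)c(=O)[nH]c1=O`: > 100 uM, a limit.

In this assay compound 1 gives only a limit, > 100 uM. Compound 3 likewise gives only a limit, > 100 uM. Compound 2 gives a number, 5 uM. Within the data shown here, the single one-place step, a step that the two limits leave unreadable from compound 1 to compound 3, cannot be read, as both ends sit at the limit of > 100 uM in this assay, at which 2 of the 3 values shown sit. Compound 3 therefore stands at the limit, with no number of its own and no readable step leading to it.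

Compound 4, `Cc1cn([C@@H]2O[C@H](CO)[C@@H](CO)[C@@H]2O)c(=O)[nH]c1=O`, differs from compound 3 by hydroxy in place of fluoro on a saturated chain carbon bound to a saturated ring carbon. No measured step bears directly on this change; the only step shown, a step that the two limits leave unreadable from compound 1 to compound 3, is unreadable. Among the measured compounds shown here, compound 2 carries a hydroxymethyl group and gives a number, but it differs from compound 4 in more than one place, so no step is drawn from it. Compound 4 is expected to remain near the limit, with an estimate of 100 uM and a range from 20 uM to 500 uM. The expected step of a number no higher from compound 3 to compound 4 (the limit leaves the size open) is accordingly expected to be small or itself unreadable.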

Compound 4, concentration for half-maximal effect: > 100 uM
Compound 4: a limit, no number (the forecaster's own chance of this, stated with the estimate: 60%); the middle value sits exactly at the limit.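

Hydroxy now joins amino and fluoro on the saturated chain carbon bound to a saturated ring carbon, and in this assay the steps among compound 1, compound 3 and compound 4 cannot be read, all three ending at the same limit: the limit of > 100 uM in this assay, at which 3 of the 4 values shown sit.

Among these compounds, the first readable step lies elsewhere: hydroxy in place of hydrogen on a saturated ring carbon gives an at least 20-fold higher number from compound 2 to compound 4 (1.30 log units; beyond the scatter). Compound 2 and compound 4 both carry hydroxymethyl, so that group alone does not secure a number in this assay.

Going by these compounds, how far amino, fluoro and hydroxy truly lie apart at this position remains open; none of the three has a number. Also open, on these data alone, is whether a carboxylic acid at this position would give a number on the core of compound 4 or on that of compound 2.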